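The source may report more compounds than this note shows. Statements on the series, on what has been measured and on what is new or still open speak of the compounds shown alone.

In an assay on HEK293 cells for inhibition of N-acylethanolamine-hydrolyzing acid amidase (Rattus norvegicus), read by LC-MS, with a stated time of 30 min (a lower number here means a stronger inhibitor, a higher number a weaker inhibitor), compound 1, with the structure `O=C(CCCCCCc1ccccc1)N1CCCC1`, gives 12900 nM. Compound 2, `Cc1cccc(CCCCCCC(=O)N2CCCC2)c1`, carries a methyl on the aromatic ring in place of a hydrogen, and in this assay compound 2 gives 8300 nM. Compound 3, `O=C(O)c1cccc(CCCCCCC(=O)N2CCCC2)c1`, carries a carboxy on that ring instead. For compound 3 this assay reports only a limit, > 100000 nM, which marks the edge of the measurement rather than a number; this is the limit of > 100000 nM in this assay, at which 1 of the 3 values shown sits. Compound 3 therefore stands at the weak end of the three, and the two steps toward it, an at least 7.7-fold higher number from compound 1 to compound 3 (0.88 log units; beyond the scatter) and an at least 12-fold higher number from compound 2 to compound 3 (1.08 log units; beyond the scatter), both ran beyond the scatter.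

Compound 4, `CCCc1cccc(CCCCCCC(=O)N2CCCC2)c1`, is reached by the change (propyl in place of carboxy on an aromatic carbon). Propyl, like methyl, is an alkyl group, and the step of a 1.6-fold lower number from compound 1 to compound 2 (0.19 log units; within the scatter) shows that such a group by itself changed little. Removing the carboxy is expected to undo the loss seen in the measured steps, so a step of an at least 12-fold lower number from compound 3 to compound 4 (1.09 log units; beyond the scatter) is expected. Compound 4 is estimated to give about 8000 nM, in a range from 3000 nM to 25000 nM.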

Compound 4, half-maximal inhibitory concentration: > 100000 nM
Compound 4: no number, only a limit; the forecaster's own chance of this, stated with the estimate: 5%; at least 12-fold (1.09 log units) between middle value and limit.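

Compound 4 gives > 100000 nM in this assay, a limit and not a number. The tolerance seen for methyl at this place on the aromatic ring does not extend to propyl, which gives an at least 7.7-fold higher number from compound 1 to compound 4 (0.88 log units; beyond the scatter) and an at least 12-fold higher number from compound 2 to compound 4 (1.08 log units; beyond the scatter). The loss is also not confined to carboxy, since propyl has no hydrogen-bond donor or acceptor yet ends at the same limit, and the step linking those two compounds cannot be read: the limit of > 100000 nM in this assay, at which 2 of the 4 values shown sit.

As far as these compounds go, whether ethyl at the same place would stay close to compound 2 or already fall to the limit remains open, as does how far the true values of compound 3 and compound 4 lie beyond it. An amine or a methoxy group at this place also remains untested among the compounds shown here.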